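The compounds below may be only part of what the source reports. "The series", "measured", "known", "first", "only" and "open" are said of these compounds alone.

Working notes on the series. Binding is read in an assay on HEK293 cells for displacement of a labelled ligand from B1 bradykinin receptor (Homo sapiens), read by scintillation counting; a lower number here means a stronger inhibitor, a higher number a weaker inhibitor. Compound 1, `COc1cc(C)c(S(=O)(=O)N(C)CCOCC(=O)N2CCC(C(C)(C)CN(C)C)CC2)c(C)c1`, gives 10 nM in this assay. Compound 2, `COc1cc(C)c(S(=O)(=O)N(C)CCOCC(=O)N2CCN([C@@H]3CN4CCC3CC4)CC2)c(C)c1`, gives 5.6 nM in this assay. Compound 3, `CN(Cc1ccc(C2=NCCN2)cc1)C(=O)COCCN(C)S(=O)(=O)c1c(Cl)cccc1Cl`, gives 4.2 nM in this assay. On these three numbers compound 2 sits between compound 3 and compound 1, and both gaps are within the usual scatter of repeated measurements, so the three cannot be ranked against one another.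

Compound 4, `CCN(CC)CCN1CCN(C(=O)COCCN(C)S(=O)(=O)c2c(C)cc(OC)cc2C)CC1`, has not been measured. It differs from compound 2 in one place: a group of 7 heavy atoms (6 carbon, 1 nitrogen; no ring) in place of a group of 8 heavy atoms (7 carbon, 1 nitrogen; 2 six-membered non-aromatic rings with 1 hetero atom each), on an amine nitrogen in a ring. For the measured compounds named here, no pair of measured compounds differing in a single place is available, so there is no measured step to lean on for this change. Compound 1, which carries a basic amine on a chain outside the ring and gives 10 nM, shows that such a group is tolerated in this assay, although compound 1 differs from compound 4 in more than one place. A small loss is expected, of a size near the edge of the scatter, as the step of a 3.6-fold higher number from compound 2 to compound 4 (0.55 log units; beyond the scatter) from compound 2 to compound 4. For compound 4 the estimate in this assay is 20 nM, with a range from 5 nM to 80 nM.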

Compound 4, inhibition constant: 10 nM
For compound 4 the middle estimate is 2.0-fold (0.30 log units) above the measured one; measured number inside the range.
By their numbers in this assay, from the lowest: compounds 3, 2, 1 and 4 (each within the scatter of the next, the first and the last beyond it).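

In this assay, for the compounds shown here, the step of a 1.8-fold higher number from compound 2 to compound 4 (0.25 log units; within the scatter) is the first measured change in one place, so this position can now be judged directly and not only through compounds that differ in several places. On the amine nitrogen in a ring, the open 2-(diethylamino)ethyl group reads the same within the scatter as the group with 2 six-membered non-aromatic rings and 1 defined stereocentre, so neither those rings nor that stereocentre is shown to be needed for binding at this level. No measurement in hand gives a reason for this result.

With a single change shown at this nitrogen, the compounds leave open whether a group with no amine at all, such as a plain butyl chain or a cyclohexyl, or a group carrying a carboxylic acid, would read alike there. They also leave open how a longer chain between the ring nitrogen and the diethylamino group, or the mirror-image form of the group in compound 2, would read.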